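This account rests on a few compounds, and the source may have more. Where it says the series, first, only, none or still open, it means among the compounds named here.

Working notes on the series. The shared core is carried by compound 1, `C[C@@]1(c2ccccc2)OCC[C@@H](CCN)O1`, and compound 2, `CC(C)(C)[C@@]1(c2ccccc2)OCC[C@@H](CCNCc2ccccc2)O1`. Compound 1 reaches only the assay limit in an assay on brain for displacement of a labelled ligand from Sigma non-opioid intracellular receptor 1 (Cavia porcellus); a higher number here means a weaker inhibitor, a lower number a stronger inhibitor: compound 1 gives > 10000 nM, which is a limit and not a number. In this assay, among the compounds with values here, compound 2 gives 128 nM, and this is the only numerical value in hand. The other entry, that of compound 1, is the limit at which one of the two values sits (the limit of > 10000 nM in this assay, at which 1 of the 2 values shown sits). Compound 3, `C[C@@]1(c2ccccc2)OCC[C@@H](CCNCc2ccccc2)O1`, has not yet been measured in this assay.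

The change from compound 2 to compound 3 is methyl in place of tert-butyl on a saturated ring carbon. Within the data shown here, no measured pair differing in one place is available to size this change, and compound 1 differs from compound 3 in the chain on the other ring carbon as well, so it does not fix the step.

For compound 3 the expectation is a weakening in this assay, with a step of a 6.3-fold higher number from compound 2 to compound 3 (0.80 log units; beyond the scatter) beyond the scatter but short of the limit. The estimate for compound 3 in this assay is 800 nM, with a range from 150 nM to 5000 nM.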

Compound 3, inhibition constant: 17 nM
For compound 3 the middle estimate is 47-fold (1.67 log units) above the measured one; measured number below the stated range.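

In this assay, the smaller group is favoured on the saturated ring carbon between two ring oxygen atoms, with methyl in place of tert-butyl giving a 7.5-fold lower number from compound 2 to compound 3 (0.88 log units; beyond the scatter), so the tert-butyl of compound 2 is not required for the affinity seen in this pair. Within the data shown here, compound 3 also gives the first one-place comparison for the amine nitrogen, where benzyl in place of hydrogen gives an at least 580-fold lower number from compound 1 to compound 3 (2.76 log units; beyond the scatter), making this the larger of the two changes now sized. Compound 1 stands at a limit and not a number, so the exact size of that step stays unknown: the limit of > 10000 nM in this assay, at which 1 of the 3 values shown sits.

On these data alone, two groups on the ring carbon define no trend, so it remains open whether an ethyl or an isopropyl group there would read closer to methyl or to tert-butyl. As far as these compounds go, on the amine nitrogen, it also remains open whether a phenethyl group, a methyl group or a benzyl group carrying a fluorine on its phenyl ring would keep the affinity that benzyl gives.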